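Carboxy in Place of Amino: Expectation for Compound 3

This account rests on a few compounds, and the source may have more. Where it says the series, first, only, none or still open, it means among the compounds named here.

compound 1, `Cn1c(-c2ccc(N)cc2Cl)nnc1C1(c2ccc(Cl)cc2)CCC1` — 2300 nM
compound 2, `Cn1c(-c2ccc(-c3cnccn3)cc2F)nnc1C1(c2ccc(Cl)cc2)CCC1` — > 4000 nM

Compound 1 holds the only number in an assay on isolated protein for inhibition of 11-beta-hydroxysteroid dehydrogenase type 2 (Homo sapiens) (on this read-out lower numbers stand for stronger inhibition and higher numbers for weaker inhibition), shown here. The value for compound 2 is a limit of the assay and not a number: the limit of > 4000 nM in this assay, at which 1 of the 2 values shown sits. Compound 3, `Cn1c(-c2ccc(C(=O)O)cc2Cl)nnc1C1(c2ccc(Cl)cc2)CCC1`, is still to be measured and differs from compound 1 by carboxy in place of amino on an aromatic carbon. Going by the values given here, no measured step covers such a change. The step of a 2.2-fold higher number from compound 1 to compound 3 (0.34 log units; beyond the scatter) is expected to go toward weaker inhibition, beyond the usual scatter. Compound 3 is estimated at 5000 nM, within 1500 nM to 20000 nM.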

Compound 3, half-maximal inhibitory concentration: > 4000 nM
Compound 3 gave a limit, no number; the forecaster's own chance of this, stated with the estimate: 50%; the middle value does not contradict the limit.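

In this assay, carboxy in place of amino on an aromatic carbon, para to a large group, gives an at least 1.7-fold higher number from compound 1 to compound 3 (0.24 log units; that floor lies within the scatter) and no measurable number for compound 3. Going by these compounds alone, that value is a limit of the assay and not a number, so the step gives only a floor, and amino remains the only group at this position with a number. The limit now holds most of the compounds shown: the limit of > 4000 nM in this assay, at which 2 of the 3 values shown sit.

Going by these compounds, how far compound 3 lies past its limit stays open. So does whether a methyl ester or a primary amide at this position would return a number.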